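A few compounds are considered here, and "the series" means these few. Any claim that something is new, unique, unknown or untested is made for them only; others in the source may bear on it.

Within the data shown here, in a functional assay on HeLa cells (Homo sapiens) for cytotoxicity, read by MTT assay (on this read-out lower numbers stand for stronger inhibition and higher numbers for weaker inhibition), only three readings exist so far, and they lie close together. Compound 1 `CCCC(CC(=O)O[C@H](CC=C(C)C)C1=CC(=O)c2c(O)ccc(O)c2C1=O)OC(C)=O` gives 51200 nM, and compound 2 `CCCC(C)(O)CC(=O)O[C@H](CC=C(C)C)C1=CC(=O)c2c(O)ccc(O)c2C1=O` gives 72000 nM. Compound 3 `CC(C)=CC[C@@H](OC(=O)C1CCCCO1)C1=CC(=O)c2c(O)ccc(O)c2C1=O` gives > 100000 nM, which is a limit of the assay and not a number.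

Compound 4 `CC(C)=CC[C@@H](OC(=O)C1CCCOC1)C1=CC(=O)c2c(O)ccc(O)c2C1=O` has the same atoms as compound 3, joined differently: oxan-3-yl in place of oxan-2-yl on a carbonyl carbon.

Among the measured compounds shown here, no measured step exchanges one of these oxane attachments for the other. The nearest evidence is the replacement of 2-acetoxypentyl or 2-hydroxy-2-methylpentyl by oxan-2-yl, which gave an at least 1.9-fold higher number from compound 1 to compound 3 (0.29 log units; that floor lies within the scatter) and an at least 1.3-fold higher number from compound 2 to compound 3 (0.14 log units; that floor lies within the scatter). The change from 1-acetoxybutyl to 1-hydroxy-1-methylbutyl gave a 1.4-fold higher number from compound 1 to compound 2 (0.15 log units; within the scatter). Each of these sizes stays within the scatter, so no step beyond the scatter is expected in this assay in either direction. Compound 4 may well report only a limit too.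

The expected change is an at least 1.1-fold lower number from compound 3 to compound 4 (0.04 log units; that floor lies within the scatter). For compound 4 the estimated value is 90000 nM, with an expected range from 45000 nM to 150000 nM.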

Compound 4, half-maximal inhibitory concentration: 60500 nM
For compound 4 the middle estimate is 1.5-fold (0.17 log units) above the measured one, and the stated range covers the measured number.
By their numbers in this assay, from the lowest: compounds 1, 4 and 2 (each within the scatter of the next). At a limit, above all of these: compound 3.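

At the carbonyl carbon, oxan-3-yl in place of oxan-2-yl gives an at least 1.6-fold lower number from compound 3 to compound 4 (0.21 log units; that floor lies within the scatter) in this assay, so this pair does not establish an effect of the ring attachment point, although the floor of the step is all that can be read.

Compound 3 stands at a limit of the assay: the limit of > 100000 nM in this assay, at which 1 of the 4 values shown sits.

The oxan-3-yl ester does give a numeric reading, and against the open chains the steps are a 1.2-fold lower number from compound 2 to compound 4 (0.08 log units; within the scatter) and a 1.2-fold higher number from compound 1 to compound 4 (0.07 log units; within the scatter), so oxan-3-yl on this carbonyl carbon is not told apart from 2-hydroxy-2-methylpentyl or 2-acetoxypentyl.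

On these data alone, whether any group on this carbonyl carbon can move the reading beyond the scatter remains open, as the three numeric readings lie within the scatter of one another. An oxan-4-yl, a chain ending in an amine or a chain ending in a carboxylic acid at the same carbonyl carbon would show whether the reading can leave this narrow band.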